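Swapping a Side Chain on a Low-Toxicity Compound

A few compounds are considered here, and "the series" means these few. Any claim that something is new, unique, unknown or untested is made for them only; others in the source may bear on it.

In an ADME assay on Huh-7 cells (Homo sapiens) for cytotoxicity, read by MTT assay, with a stated time of 4 h, at 37 degrees C (on this read-out higher numbers stand for lower toxicity in this test and lower numbers for higher toxicity in this test), compound 1 (`COCCn1c(=O)c(-c2c(Cl)cccc2Cl)cc2c(N)nc(Nc3ccccc3)nc21`) gives 241000 nM. Going by the values given here, that is the higher of the two numbers measured so far, and it lies beyond the usual scatter from compound 2 (`CSc1nc2c(c(=O)[nH]1)CC(Cc1ccccc1)C(=O)N2`), which gives 38300 nM. Compound 3 (`CC(C)Cn1c(=O)c(-c2c(Cl)cccc2Cl)cc2c(N)nc(Nc3ccccc3)nc21`) keeps the core of compound 1 but carries isopropyl in place of methoxymethyl on a saturated chain carbon bound to an aromatic nitrogen. Cut one bond further out, the same difference reads 2-methoxyethyl to isobutyl. Among the compounds with values here, no two measured compounds differ in just one place, so the data offer no direct guide to the size of this change in this assay. Within the data shown here, a modest fall is expected, an estimated 2.0-fold lower number from compound 1 to compound 3 (0.30 log units; within the scatter), because compound 1 at 241000 nM is the higher of only two values. The expected value for compound 3 is 120000 nM, with an estimated range of 40000 nM to 300000 nM.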

Compound 3, half-maximal cytotoxic concentration: 185000 nM
Compound 3: middle estimate off by 1.5-fold (0.19 log units), on the low side; measured number inside the range.
By their numbers in this assay, from the lowest: compound 2; then compounds 3 and 1 (each within the scatter of the next).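

Going by these compounds alone, this is the first pair that differs in just one place, and it gives a size for a change on a saturated chain carbon bound to an aromatic nitrogen in this assay: the step is a 1.3-fold lower number from compound 1 to compound 3 (0.11 log units; within the scatter). Isopropyl has the same count of heavy atoms as methoxymethyl but carries no oxygen and no hydrogen-bond acceptor, so in this pair, losing that oxygen leaves the two compounds indistinguishable on this read-out. Nothing available explains the result.

One pair cannot show how much freedom this place allows in general. From the compounds shown here alone, whether an amine, a carboxylic acid or a much longer chain in this place would move the number beyond the scatter remains open, as does whether the same swap behaves alike on another core.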